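The source may hold more compounds than are shown below. What is called first, only, known or untested is meant among the compounds shown, and "the series" means these compounds.

Of the compounds shown here, two built on a shared core have been measured in an in vitro functional assay on cells for agonist activity at Bombesin receptor subtype-3 (Mus musculus), read by luminescence and calcium flux; a higher number here means that more compound is needed for the effect, a lower number that less compound is needed. Compound 1 `O=C(O)c1ccccc1-c1ccc(CCc2ncc(Cc3ccccc3F)[nH]2)cc1` gives 9.5 nM in this assay. Compound 2 `CCC(C)(C)Cc1c[nH]c(CCc2ccc(-c3ccccc3C(=O)O)cc2)n1`, which carries a different group on the same core, gives 9.6 nM. Compound 1 holds the lower of the two numbers, but the gap to compound 2 is within the usual scatter of repeated measurements, so the two compounds cannot be told apart on these data.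

Compound 3 `N#Cc1ccccc1Cc1cnc(CCc2ccc(-c3ccccc3C(=O)O)cc2)[nH]1` has not yet been measured. It differs from compound 1 by a single change: cyano in place of fluoro on an aromatic carbon. Among the measured compounds shown here, no measured pair in this set shows a change of this kind, so the size of the step cannot be read from neighbouring data. An exchange of one group for another on the 2-fluorobenzyl part is expected to shift the value only modestly, in either direction, and possibly not beyond the scatter. Compound 3 is therefore expected to give about 12 nM, within a range of 4 nM to 40 nM, which corresponds to an expected step of a 1.3-fold higher number from compound 1 to compound 3 (0.10 log units; within the scatter).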

Compound 3, half-maximal effective concentration: 642 nM
Estimate against measurement, compound 3: 54-fold (1.73 log units) below; the whole stated range lies below it.
By their numbers in this assay, from the lowest: compounds 1 and 2 (each within the scatter of the next); then compound 3.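

In this assay, the exchange of fluoro for cyano on the 2-fluorobenzyl part gives a 68-fold higher number from compound 1 to compound 3 (1.83 log units; beyond the scatter) and so is far from a minor edit. Compounds 1 and 2 could not be told apart despite carrying different groups on the shared core, which gave no sign that one aromatic position could matter this much. Here a single fluorine ortho to a large group gives way to a carbon and a nitrogen joined by a triple bond, yet nothing measured here says why the number rises so steeply.

The compounds shown leave open whether this step belongs to cyano itself or would follow from any replacement of fluoro at this place, a question that chloro, methyl, methoxy or plain hydrogen on the same carbon could help to settle. They also leave open whether a cyano group elsewhere on the same ring, or the same exchange made in a compound with a different group on the core, would produce a step of similar size.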